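This account rests on a few compounds, and the source may have more. Where it says the series, first, only, none or still open, it means among the compounds named here.

Compound 3 `CC(C)[C@H](NC(=O)COc1cccc2ccccc12)C(=O)N[C@@H](CC(=O)O)C(=O)COc1nc2ccccc2[nH]1` carries a (1H-benzimidazol-2-yl)oxy group on a saturated chain carbon bound to a carbonyl carbon. In a functional assay on Jurkat cells (Homo sapiens) for inhibition (on this read-out higher numbers stand for weaker inhibition and lower numbers for stronger inhibition), compound 3 gives only a limit, > 200000 nM. Compound 1 `CC(C)[C@H](NC(=O)COc1cccc2ccccc12)C(=O)N[C@@H](CC(=O)O)C(=O)CSC1=NCCS1` also gives only a limit in this assay, > 200000 nM. For the measured compounds named here, compound 2 `CC(C)[C@H](NC(=O)COc1cccc2ccccc12)C(=O)N[C@@H](CC(=O)O)C(=O)CSc1nnnn1-c1ccccc1` is the one compound with a number, and in this assay compound 2 gives 153000 nM. The step of an at least 1.3-fold lower number from compound 1 to compound 2 (0.11 log units; that floor lies within the scatter) and the step of an at least 1.3-fold higher number from compound 2 to compound 3 (0.11 log units; that floor lies within the scatter) both lie within the scatter, while the step that the two limits leave unreadable from compound 1 to compound 3 cannot be read, so compound 3 stands among uniformly weak inhibitors, as the limit of > 200000 nM in this assay, at which 2 of the 3 values shown sit, makes plain.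

Compound 4 `CC(C)[C@H](NC(=O)COc1cccc2ccccc12)C(=O)N[C@@H](CC(=O)O)C(=O)COc1cc2ccccc2cn1` differs from compound 3 by isoquinolin-3-yl in place of 1H-benzimidazol-2-yl on an oxygen on a saturated carbon. No measured step exchanges one such ring for another, and every step shown is within the scatter or unreadable, so the step from compound 3 to compound 4 is expected to stay within the scatter, a number no higher from compound 3 to compound 4 (the limit leaves the size open). Compound 4 is therefore estimated to give 200000 nM in this assay, within a range from 50000 nM to 1000000 nM.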

Compound 4, half-maximal inhibitory concentration: > 200000 nM
Compound 4: a limit, no number; the forecaster's own chance of this, stated with the estimate: 70%; the middle value lies on the limit itself.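

Exchanging the five-membered ring of the benzimidazole for the six-membered nitrogen ring of isoquinolin-3-yl on the oxygen, which also goes from 1 hydrogen-bond donor to 0, still brings no measurable inhibition in this assay, and the result again rests on a limit: the limit of > 200000 nM in this assay, at which 3 of the 4 values shown sit. Against compound 2, the only compound with a number, the change from the sulfur-linked tetrazole gives an at least 1.3-fold higher number from compound 2 to compound 4 (0.11 log units; that floor lies within the scatter), so this second oxygen-linked group does not separate itself from that compound. The steps from compound 3 to compound 4 and from compound 1 to compound 4 cannot be read, since both ends of each are limits.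

On these data alone, how far compound 3 and compound 4 differ therefore stays open. As far as these compounds go, it also remains open whether an amine on the isoquinoline ring, or an ester in place of the carboxylic acid, would give a value clear of the limit.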